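Swapping Phenoxy for Dimethylamino in a Cytotoxicity Series

This account rests on a few compounds, and the source may have more. Where it says the series, first, only, none or still open, it means among the compounds named here.

Two measured compounds, compound 1 `COc1cc(C)cc(-c2c(-c3ccnc(-c4ccc(C(C)=O)cc4)c3)cnn2CC#N)c1` and compound 2 `Cc1cc(O)cc(-c2nn(CC#N)cc2-c2ccnc(-c3ccc(Oc4ccccc4)cc3)c2)c1`, share a core and differ in one outer group. In a functional assay on BT-549 cells (Homo sapiens) for cytotoxicity, read by sulforhodamine B assay, with a stated time of 48 h, tested at 0.001 uM (on this read-out higher numbers stand for a weaker effect at the one concentration tested and lower numbers for a stronger effect), compound 1 gives 96% and compound 2 gives 96%; the two values are level at the digits shown, within the usual scatter of this kind of measurement. Compound 2 therefore stands where compound 1 stands, with almost no loss of cell growth at the single low concentration tested.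

Compound 3 `Cc1cc(O)cc(-c2nn(CC#N)cc2-c2ccnc(-c3ccc(N(C)C)cc3)c2)c1` has not yet been measured. It differs from compound 2 in one place: dimethylamino in place of phenoxy on an aromatic carbon. Among the compounds with values here, no measured pair in this set differs by only one change, so there is no earlier step to lean on. Because compound 1 gives 96% and compound 2 gives 96% while carrying different groups at that position, and because both sit near the top of the scale, the step is expected to be small, none beyond the scatter a number 1 percentage points lower from compound 2 to compound 3 (within the scatter). Compound 3 is therefore expected to give about 95% in this assay, within a range from 85% to 102%.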

Compound 3, a percentage reported as activity, at one concentration (the size of the read-out at that concentration, not a potency): 96%
Estimate against measurement, compound 3: 1 percentage points below; low and high end bracket the measured number.
By their numbers in this assay, from the lowest: compounds 1, 2 and 3 (each within the scatter of the next).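

In this assay, within the data shown here, dimethylamino in place of phenoxy, on an aromatic carbon para to a large group, gives no change at the digits printed from compound 2 to compound 3 (within the scatter) and provides the first direct comparison at this position. The change removes a group of 7 heavy atoms with a six-membered aromatic ring and puts in one of 3 heavy atoms with no ring, yet the read-out stays level, so at this single low concentration the size of the group and the presence of its ring do not show up in the result. No data shown here give a reason for this level result or a measured property of either group.

The compounds shown leave open whether a carboxylic acid or a longer alkyl chain at this position would move the read-out beyond the scatter. They also leave open whether compound 2 and compound 3 would still match at higher concentrations, where a single low-dose reading near the top of the scale could give way to a measurable effect.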